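From an aryl urea to a benzyl urea

The source may hold more compounds than are shown below. What is called first, only, known or untested is meant among the compounds shown, and "the series" means these compounds.

compound 1 `O=C(NCCCOc1cccc(CN2CCCCC2)c1)Nc1ccccc1` gives 126 nM in an assay on isolated protein for inhibition of histamine H2 receptor (Cavia porcellus); a higher number here means weaker binding, a lower number tighter binding
compound 2 `O=C(NCCCOc1cccc(CN2CCCCC2)c1)Nc1cccc(C(F)(F)F)c1` gives 813 nM in this assay

Among the two measured compounds, compound 2 has the higher number, and its only neighbour is compound 1: the one measured step is a 6.5-fold higher number from compound 1 to compound 2 (0.81 log units; beyond the scatter). Compound 3 `O=C(NCCCOc1cccc(CN2CCCCC2)c1)NCc1ccccc1` is the next member. Compared with compound 2 it carries benzyl in place of 3-(trifluoromethyl)phenyl on an amide-type nitrogen. The change to compound 3 removes the trifluoromethyl. That trifluoromethyl is what a 6.5-fold higher number from compound 1 to compound 2 (0.81 log units; beyond the scatter) had introduced, so that single measured step is the one that bears on it; the second part of the change, a benzyl in place of a phenyl on the amide-type nitrogen, has no measured counterpart among these compounds and its size is unknown. On the strength of the measured step alone, compound 3 is expected to return most of the way toward compound 1, a step of about a 5.1-fold lower number from compound 2 to compound 3 (0.71 log units; beyond the scatter) in this assay. The estimate for compound 3 is therefore 160 nM, with a range from 40 nM to 650 nM.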

Compound 3, dissociation constant: 347 nM
Compound 3: middle estimate off by 2.2-fold (0.34 log units), on the low side; the measured number falls inside the stated range.
By their numbers in this assay, from the lowest: compound 1; then compound 3; then compound 2.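

In this assay, the amide-type nitrogen proves sensitive to more than the trifluoromethyl: benzyl in place of phenyl, with no fluorine involved, gives a 2.8-fold higher number from compound 1 to compound 3 (0.44 log units; beyond the scatter) and so weakens binding by itself. Benzyl in place of 3-(trifluoromethyl)phenyl gives a 2.3-fold lower number from compound 2 to compound 3 (0.37 log units; beyond the scatter), which recovers only part of the loss and shows that removing the trifluoromethyl does not restore compound 1 when the benzyl comes with it; among these three compounds, the unsubstituted phenyl on this nitrogen gives the tightest binding, with its steps to both others beyond the scatter. No measurement at hand bears on the reason for this order.

The compounds shown leave open whether a trifluoromethyl on the benzyl ring would raise the number as it does on the phenyl ring, and whether a longer chain such as phenethyl on the same nitrogen would continue the rise seen with benzyl. They also leave open how a nitrile or an amine would read in the place the trifluoromethyl holds on the phenyl ring.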